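The source may hold more compounds than are shown below. What is called first, only, known or untested is meant among the compounds shown, and "the series" means these compounds.

Among the compounds with values here, compound 1 `COc1cc(-c2ccnc3cc(-c4ccc5cc[nH]c5c4)nn23)cc(OC)c1OC` is the only compound in this set that yields a number in a functional assay on B16-F0 cells (Mus musculus) for inhibition, read by CCK-8 assay, with a stated time of 48 h (on this read-out higher numbers stand for weaker inhibition and lower numbers for stronger inhibition), where compound 1 gives 55 nM. Compound 2 `COc1cc(-c2ccnc3c(-c4ccc(C)cc4)cnn23)cc(OC)c1OC` yields only a limit of the measurement, namely > 10000 nM. Compound 3 `COc1ccc(-c2cc3nccc(-c4cc(OC)c(OC)c(OC)c4)n3n2)cc1[N+](=O)[O-]` likewise yields only a limit, namely > 10000 nM. Within the data shown here, no two measured compounds differ in a single place, so no measured step guides the next change. Compound 4 `COc1cc(-c2ccnc3cc(-c4ccc5ccn(C)c5c4)nn23)cc(OC)c1OC` differs from compound 1 by methyl in place of hydrogen on an aromatic nitrogen. The expected step of a 1.6-fold higher number from compound 1 to compound 4 (0.21 log units; within the scatter) is small, not beyond the usual scatter of repeated measurements, with somewhat weaker inhibition slightly more likely than stronger. Compound 4 is therefore estimated at 90 nM, with a range from 25 nM to 400 nM.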

Compound 4, half-maximal inhibitory concentration: 657 nM
For compound 4 the middle estimate is 7.3-fold (0.86 log units) below the measured one, outside the stated range (above it).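

In this assay, going from 1H-indol-6-yl to 1-methyl-1H-indol-6-yl gives a 12-fold higher number from compound 1 to compound 4 (1.08 log units; beyond the scatter), so one added methyl on this aromatic nitrogen clearly weakens inhibition. This is the only single-place step among the compounds shown, and it marks the hydrogen at this position as sensitive to replacement. Even so, compound 4 still gives a number rather than a limit.

Nothing shown explains why this methyl weakens inhibition so much. Open, on these data alone, is how an ethyl group, a longer chain or a chain ending in an amine on this nitrogen would compare.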